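Aryl replacement at the quinolinone core: compound 3

The source may report more compounds than this note shows. Statements on the series, on what has been measured and on what is new or still open speak of the compounds shown alone.

Measured so far:
compound 1, `COc1ncc(-c2cc3c(C)nc(N)nc3n([C@H]3CC[C@H](OCO)CC3)c2=O)cc1F`, gives 5.24 nM in an assay on BT-20 cells for inhibition of RAC-alpha serine/threonine-protein kinase (Homo sapiens); a higher number here means a weaker inhibitor, a lower number a stronger inhibitor.
compound 2, `Cc1nc(N)nc2c1cc(-c1cn[nH]c1)c(=O)n2[C@H]1CC[C@H](OCO)CC1`, gives 25.9 nM in this assay.

Compound 2 stands highest of the two numbers measured; its nearest neighbour is compound 1, and the step of a 4.9-fold higher number from compound 1 to compound 2 (0.69 log units; beyond the scatter) lies beyond the scatter.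

Compound 3, `Cc1nc(N)nc2c1cc(-c1cnc3ccccc3c1)c(=O)n2[C@H]1CC[C@H](OCO)CC1`, is not yet measured. It differs from compound 2 in one place: quinolin-3-yl in place of 1H-pyrazol-4-yl on an aromatic carbon. For the measured compounds named here, the only measured step that bears on this change is a 4.9-fold higher number from compound 1 to compound 2 (0.69 log units; beyond the scatter), where the pyrazolyl group in place of a six-membered aromatic group gave the higher number. Going by the values given here, that step is the sole guide here; no measured pair carries a quinolin-3-yl group. For compound 3 a lower number than for compound 2 is therefore expected in this assay, of roughly the size seen in that one step, a 3.2-fold lower number from compound 2 to compound 3 (0.51 log units; beyond the scatter). The estimate for compound 3 is 8 nM, with a range from 3 nM to 25 nM.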

Compound 3, half-maximal inhibitory concentration: 23.8 nM
Beside the measured number, compound 3's estimate is 3.0-fold (0.47 log units) below it; the range from low to high includes it.
By their numbers in this assay, from the lowest: compound 1; then compounds 3 and 2 (each within the scatter of the next).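

In this assay, swapping the 1H-pyrazol-4-yl group, with its hydrogen-bond donor, for the larger quinolin-3-yl group of 10 heavy atoms and no donor leaves the read-out within the scatter (a 1.1-fold lower number from compound 2 to compound 3 (0.04 log units; within the scatter)). The earlier step from a six-membered aromatic group to the pyrazolyl group therefore cannot be read as a general preference for a six-membered aromatic ring at this position. For the compounds shown here, compound 3 carries such a ring yet stays apart from compound 1 (a 4.5-fold higher number from compound 1 to compound 3 (0.66 log units; beyond the scatter)), so the lower number so far belongs only to the 5-fluoro-6-methoxypyridin-3-yl group of compound 1.

The data offer no measured explanation for these results. Open, on these data alone, is whether an unsubstituted pyridin-3-yl group, or one carrying only the methoxy group or only the fluorine, would group with compound 1 or with compound 2 and compound 3.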